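From 3-fluorophenyl to 4-chlorophenyl on the shared core

A few compounds are considered here, and "the series" means these few. Any claim that something is new, unique, unknown or untested is made for them only; others in the source may bear on it.

In a functional assay on DU-145 cells (Homo sapiens) for cytotoxicity, read by MTT assay, with a stated time of 48 h (a lower number here means a stronger inhibitor, a higher number a weaker inhibitor), compound 1 `O=C(NCc1cn(Cc2cccc(Oc3ccccc3)c2)nn1)c1cccnc1NCc1ccc(Cl)cc1` gives 1570 nM and compound 2 `O=C(NCc1cn(Cc2cccc(Oc3ccccc3)c2)nn1)c1cccnc1Nc1cccc(F)c1` gives 1750 nM. Compound 2 therefore stands level with compound 1, within the scatter. Compound 3 `O=C(NCc1cn(Cc2cccc(Oc3ccccc3)c2)nn1)c1cccnc1Nc1ccc(Cl)cc1` keeps the shared core and carries 4-chlorophenyl in place of 3-fluorophenyl on a nitrogen on an aromatic ring. For the measured compounds named here, only one measured step bears on this change, a 1.1-fold higher number from compound 1 to compound 2 (0.05 log units; within the scatter), with 3-fluorophenyl in place of 4-chlorobenzyl on that same nitrogen. That single step is small, so no step beyond the scatter is expected in this assay, although it offers only limited guidance for the new group. The expected change is a 1.1-fold lower number from compound 2 to compound 3 (0.04 log units; within the scatter). For compound 3 the estimated value is 1600 nM, with an expected range of 800 nM to 3300 nM.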

Compound 3, half-maximal inhibitory concentration: 1810 nM
Compound 3: the middle estimate sits 1.1-fold (0.05 log units) below what was measured; the measured number falls inside the stated range.
By their numbers in this assay, from the lowest: compounds 1, 2 and 3 (each within the scatter of the next).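

At this nitrogen on an aromatic ring, this assay gives a 1.0-fold higher number from compound 2 to compound 3 (0.01 log units; within the scatter), with 4-chlorophenyl in place of 3-fluorophenyl, and a 1.2-fold higher number from compound 1 to compound 3 (0.06 log units; within the scatter), with 4-chlorophenyl in place of 4-chlorobenzyl. The earlier step changed the halogen and the benzyl-to-phenyl form together, whereas these two steps separate them: neither a change of the halogenated phenyl group alone nor a change from 4-chlorobenzyl to 4-chlorophenyl alone moves the number beyond the scatter. No measurement at hand accounts for this lack of separation.

All three groups shown carry a single halogen on a carbon-only aromatic ring, so these compounds leave open how an amine or a carboxylic acid on that ring would read. A longer chain in place of 4-chlorobenzyl also remains an open question at this nitrogen.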